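The source may hold more compounds than are shown below. What is called first, only, known or untested is meant among the compounds shown, and "the series" means these compounds.

Four compounds share one core and differ only in the groups at their ends. Compound 1 `CN(C(=O)NC(=O)c1c(F)cccc1F)c1nc(C(F)(F)F)c(C(=O)N/N=C/c2cc(C(F)(F)F)cc(C(F)(F)F)c2)s1` was tested in an ADME assay on L02 cells (Homo sapiens) for inhibition, read by MTT assay, with a stated time of 72 h (a lower number here means a stronger inhibitor, a higher number a weaker inhibitor), where compound 1 gives "not determined" (no result reported). Compound 3 `CN(C(=O)NC(=O)c1ccccc1F)c1nc(C(F)(F)F)c(C(=O)N/N=C/c2cccc(C(F)(F)F)c2)s1` was tested in the same way, and in this assay compound 3 gives "not determined" (no result reported). Compound 2 `CN(C(=O)NC(=O)c1ccc(F)c(F)c1)c1nc(C(F)(F)F)c(C(=O)N/N=C/c2cccc(C(F)(F)F)c2)s1` is therefore the only one of the measured set that gives a figure: in this assay compound 2 gives 23.5 ug/mL, and with nothing else to compare it against, this single value is the whole of what is known about where the series sits.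

Compound 4 `CN(C(=O)NC(=O)c1ccc(F)c(F)c1)c1nc(C(F)(F)F)c(C(=O)N/N=C/c2cc(C(F)(F)F)cc(C(F)(F)F)c2)s1` has not yet been measured. It is built from compound 2 by one change: trifluoromethyl in place of hydrogen on an aromatic carbon. The new group enters on an aromatic carbon of a six-membered aromatic ring of carbon only, meta to a trifluoromethyl group that is already there.

Within the data shown here, no step between two measured compounds is available, so nothing in the data shows how such a change has moved the read-out before. The most cautious view is that the change is expected to amount to a 1.1-fold lower number from compound 2 to compound 4 (0.03 log units; within the scatter), a shift that stays within the usual scatter of repeated measurements, with no direction favoured. On that basis compound 4 is expected to give 22 ug/mL in this assay, with a range from 9 ug/mL to 55 ug/mL.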

Compound 4, half-maximal inhibitory concentration: 20.1 ug/mL
Beside the measured number, compound 4's estimate is 1.1-fold (0.04 log units) above it, within the range that was stated.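

Among these compounds, this is the first step that can be read: in this assay, adding trifluoromethyl in place of hydrogen on this aromatic carbon gives a 1.2-fold lower number from compound 2 to compound 4 (0.07 log units; within the scatter). The read-out therefore does not separate the two compounds, even though the new group sits meta to a trifluoromethyl group already on the ring and brings four heavy atoms where there was only a hydrogen. In this one pair, the position accepts that addition with no shift larger than the differences seen between repeated measurements, and nothing available bears on why this is so.

This single pair cannot show whether the result is particular to trifluoromethyl, as a methyl group, an amine or a carboxylic acid on the same aromatic carbon might give a quite different number. It also leaves open whether the same change would again make so little difference in this assay with a different group at the other end of the molecule.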